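A formyl group in place of methoxy on compound 2

The source may hold more compounds than are shown below. What is called first, only, known or untested is meant among the compounds shown, and "the series" means these compounds.

Compound 1 `c1ccc(-c2cn3ccnc3c(-c3ccc4ncn(C5CCCCC5)c4c3)n2)cc1` and compound 2 `COc1ccc(-c2cn3ccnc3c(-c3ccc4ncn(C5CCCCC5)c4c3)n2)cc1` share one core and differ at a single aromatic carbon. Going by the values given here, in a functional assay on NCI-H460 cells (Homo sapiens) for inhibition, read by sulforhodamine B assay, with a stated time of 48 h, tested at 10 uM (a higher number here means more inhibition at the concentration tested (going by the name of the read-out), a lower number less inhibition), compound 1 gives 37.8%, while compound 2 gives 91.1%, the higher of the two numbers measured so far. The step of a number 53.3 percentage points higher from compound 1 to compound 2 (beyond the scatter) shows that methoxy in place of hydrogen at this carbon raised inhibition well beyond the usual scatter. Compound 3 `O=Cc1ccc(-c2cn3ccnc3c(-c3ccc4ncn(C5CCCCC5)c4c3)n2)cc1` carries a different group at the same place: formyl in place of methoxy on an aromatic carbon. Among the compounds with values here, no measured step covers this exchange. Within the data shown here, the one step from compound 1 to compound 2 bears on it only indirectly, in showing that inhibition responds strongly to what sits at this position; whether the gain seen in compound 2 belongs to methoxy itself or would survive another group of similar size cannot be read from two compounds. The step of a number 29.1 percentage points lower from compound 2 to compound 3 (beyond the scatter) is therefore expected to be a loss of moderate size, with wide uncertainty in both directions. Compound 3 is estimated at 62%, within a range from 25% to 92%.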

Compound 3, a percentage reported as inhibition, at one concentration (the size of the read-out at that concentration, not a potency): 37.8%
Beside the measured number, compound 3's estimate is 24.2 percentage points above it; the range from low to high includes it.
By their numbers in this assay, from the lowest: compounds 1 and 3 (each within the scatter of the next); then compound 2.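

In this assay, the exchange of methoxy for formyl is a large loss (a number 53.3 percentage points lower from compound 2 to compound 3 (beyond the scatter)), although the two groups have the same count of heavy atoms and of hydrogen-bond acceptors, so those counts alone do not account for the high number of compound 2. Formyl in place of hydrogen gives no gain at all (no change at the digits printed from compound 1 to compound 3 (within the scatter)), which means that, among these three compounds, a substituent at this place on the aromatic ring does not by itself raise inhibition, and only methoxy stands apart. Nothing measured here explains why methoxy and formyl differ so sharply at this position.

The compounds shown leave open whether any other group at this place, such as ethoxy, hydroxyl, an amine or a carboxylic acid, would match methoxy or fall back to the level shared by compound 1 and compound 3. As far as these compounds go, each number is also a read-out at one concentration, so how potency differs among the three compounds remains unknown.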